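Benzyl for methylcarbamoyl on the sulfonamide side chain

The source may report more compounds than this note shows. Statements on the series, on what has been measured and on what is new or still open speak of the compounds shown alone.

Compound 1 `CC(C)S(=O)(=O)NC(=O)c1ccc(Nc2nc(NC3(c4ccc(Cl)cc4)CC3)nc(OCC(F)(F)F)n2)cc1`: 31 nm/s
Compound 2 `CC(C)(C)CNCCS(=O)(=O)NC(=O)c1ccc(Nc2nc(NC3(c4ccc(Cl)cc4)CC3)nc(OCC(F)(F)F)n2)cc1`: 651 nm/s
Compound 3 `CNC(=O)NCCS(=O)(=O)NC(=O)c1ccc(Nc2nc(NC3(c4ccc(Cl)cc4)CC3)nc(OCC(F)(F)F)n2)cc1`: 40 nm/s

Three analogues sharing one core were measured in a physicochemical assay for permeability, using PAMPA, at pH 7.4; a lower number here means that the compound crosses the layer more slowly, a higher number that the compound crosses the layer faster. Compound 3 stands second highest of the three; its number and that of compound 1 lie within the scatter, a 1.3-fold higher number from compound 1 to compound 3 (0.11 log units; within the scatter), whereas compound 2 sits far above, a 16-fold lower number from compound 2 to compound 3 (1.21 log units; beyond the scatter). Compound 4 `O=C(NS(=O)(=O)CCNCc1ccccc1)c1ccc(Nc2nc(NC3(c4ccc(Cl)cc4)CC3)nc(OCC(F)(F)F)n2)cc1` differs from compound 3 in one place: benzyl in place of methylcarbamoyl on an amine nitrogen. Among the compounds with values here, the step that bears on this is the one from compound 2 to compound 3, which was large, as was a 21-fold higher number from compound 1 to compound 2 (1.32 log units; beyond the scatter). Compound 4 carries a substituted amine like compound 2, so a large rise is expected, a 10-fold higher number from compound 3 to compound 4 (1.00 log units; beyond the scatter). Compound 4 is therefore estimated at 400 nm/s, with a range of 150 nm/s to 1000 nm/s.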

Compound 4, apparent permeability: 49 nm/s
The estimate for compound 4 lay 8.2-fold (0.91 log units) above the measured number; the measured number lies below the stated range.
By their numbers in this assay, from the lowest: compounds 1, 3 and 4 (each within the scatter of the next); then compound 2.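

In this assay, an amine in the side chain does not by itself go with a high number: benzyl in place of methylcarbamoyl on the amine nitrogen gives a 1.2-fold higher number from compound 3 to compound 4 (0.09 log units; within the scatter), and 2-(benzylamino)ethyl in place of isopropyl on the sulfonyl sulfur gives a 1.6-fold higher number from compound 1 to compound 4 (0.20 log units; within the scatter). Compound 2 stands apart, with phenyl in place of tert-butyl on the saturated chain carbon giving a 13-fold lower number from compound 2 to compound 4 (1.12 log units; beyond the scatter), so among these compounds the high number goes with neopentyl on that nitrogen. No measurement shown accounts for this difference.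

On these data alone, it remains open whether another saturated group on that amine nitrogen, such as isobutyl or cyclohexylmethyl, would stand with compound 2 or with compound 4.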